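Aryl variation on the shared core: Vero cytotoxicity notes

The compounds below may be only part of what the source reports. "The series", "measured", "known", "first", "only" and "open" are said of these compounds alone.

Measured so far:
compound 1 `O=C1CSC(c2c(Cl)cccc2Cl)N1CCN1CCCCC1` gives 10%
compound 2 `O=C1CSC(c2cccc(O)c2)N1CCN1CCCCC1` gives 13%
compound 3 `O=C1CSC(c2ccccc2[N+](=O)[O-])N1CCN1CCCCC1` gives 24%

All three numbers come from an ADME assay on Vero cells (Chlorocebus sabaeus) for cytotoxicity, read by neutral red uptake, tested at 1575 ug/mL; a higher number here means a weaker effect of the compound at the concentration tested, a lower number a stronger effect. Compound 2 stands second highest of the three. Its nearest neighbour is compound 1, whose number is lower by an amount within the scatter, so the two cannot be told apart here. Compound 3 lies furthest from compound 2, with a number higher by an amount beyond the scatter.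

Compound 4 `O=C1CSC(c2ccccc2Cl)N1CCN1CCCCC1` is not yet measured in this assay. It differs from compound 2 at one place:
2-chlorophenyl in place of 3-hydroxyphenyl on a saturated ring carbon
Among the measured compounds shown here, no step between two measured compounds covers this exact change, so the expectation rests on the standing of compound 2 and the fact that compound 1, which also carries chlorine on its aryl group, gives 10% within the scatter of compound 2. The step is therefore expected to be small, of either sign, and not beyond the scatter: a number 1 percentage points lower from compound 2 to compound 4 (within the scatter). Compound 4 is estimated at 12%, with a range from 5% to 22%.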

Compound 4, a percentage reported as activity, at one concentration (the size of the read-out at that concentration, not a potency): 16%
For compound 4 the middle estimate is 4 percentage points below the measured one; low and high end bracket the measured number.
By their numbers in this assay, from the lowest: compounds 1, 2, 4 and 3 (each within the scatter of the next, the first and the last beyond it).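

In this assay, 2-chlorophenyl in place of 3-hydroxyphenyl on the saturated ring carbon gives a number 3 percentage points higher from compound 2 to compound 4 (within the scatter), so at this position the exchange of a hydroxyl-bearing aryl group for a chlorine-bearing one cannot be told from the scatter. Among the compounds shown here, compound 4 also supplies the first single-substituent steps on the aryl group: chloro in place of nitro gives a number 8 percentage points lower from compound 3 to compound 4 (within the scatter), and hydrogen in place of chloro gives a number 6 percentage points higher from compound 1 to compound 4 (within the scatter), and neither step can be told from the scatter. No measurement at hand bears on what lies behind these readings.

Going by these compounds, whether an amine or a carboxylic acid on the aryl group would give a step beyond the scatter remains open. The same holds for a plain alkyl chain in place of the aryl group at this position.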